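The compounds below may be only part of what the source reports. "The series", "measured", "known", "first", "only" and "open" are said of these compounds alone.

Measured in a functional assay on ACHN cells (Homo sapiens) for antiproliferative activity, read by sulforhodamine B assay; a lower number here means a stronger inhibitor of growth, a higher number a weaker inhibitor of growth:
- compound 1 `CC(C)CCCOc1cccc(O)c1C(=O)/C=C/c1ccc(O)cc1`: 3630 nM
- compound 2 `CCCCOc1cccc(O)c1C(=O)/C=C/c1ccc(O)cc1`: > 30000 nM (a limit of the assay, not a number)
- compound 3 `CCC(CC)COc1cccc(O)c1C(=O)/C=C/c1ccc(O)cc1`: 3370 nM

Among the compounds with values here, compound 3 stands level with the only other numerical value, the step being a 1.1-fold lower number from compound 1 to compound 3 (0.03 log units; within the scatter). Compound 4 `O=C(/C=C/c1ccc(O)cc1)c1c(O)cccc1OCc1ccccc1` differs from compound 3 by phenyl in place of pentan-3-yl on a saturated chain carbon bound to an oxygen on an aromatic ring. Within the data shown here, the closest precedent is that same exchange of one larger group for another at this place, a 1.1-fold lower number from compound 1 to compound 3 (0.03 log units; within the scatter), so no step beyond the scatter is expected. Among the measured compounds shown here, the range stays wide on the upper side, given an at least 8.2-fold higher number from compound 1 to compound 2 (0.91 log units; beyond the scatter) and an at least 8.9-fold lower number from compound 2 to compound 3 (0.94 log units; beyond the scatter), and no measured compound carries a ring there. The expected step is a 1.5-fold higher number from compound 3 to compound 4 (0.17 log units; within the scatter). Compound 4 is estimated at 5000 nM, with an expected range of 1800 nM to 20000 nM.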

Compound 4, concentration for 50% growth inhibition: > 30000 nM
Compound 4: only a limit was reported (the forecaster's own chance of this, stated with the estimate: 15%); middle value at least 6.0-fold (0.77 log units) away from the limit.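

At the saturated chain carbon bound to an oxygen on an aromatic ring, the exchange of one larger group for another is not always neutral: phenyl in place of pentan-3-yl gives an at least 8.9-fold higher number from compound 3 to compound 4 (0.94 log units; beyond the scatter), and phenyl in place of isopentyl gives an at least 8.2-fold higher number from compound 1 to compound 4 (0.91 log units; beyond the scatter). The level standing of compound 1 and compound 3 therefore does not extend to benzyloxy, the only ring shown at this place. The step between compound 2 and compound 4 cannot be read, as both values are limits: the limit of > 30000 nM in this assay, at which 2 of the 4 values shown sit.

As far as these compounds go, whether a cyclohexylmethyl group or a phenethyl group would behave like benzyl or like 2-ethylbutyl remains open. From the compounds shown here alone, how far compound 4 lies beyond its limit also remains open.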